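A few compounds are considered here, and "the series" means these few. Any claim that something is new, unique, unknown or untested is made for them only; others in the source may bear on it.

Measured compounds:
compound 1, `O=C(O)CCc1ccc(C#Cc2ccnc(-c3ccccc3)c2)cc1`, in an in vitro functional assay on 1321-N1 cells for agonist activity at Free fatty acid receptor 1 (Homo sapiens), read by fluorescence, spectrophotometry and calcium flux (a lower number here means that less compound is needed, a higher number that more compound is needed for the effect), gives 186 nM;
compound 2, `O=C(O)CCc1ccc(C#Cc2ccc(Cl)nc2)cc1`, in this assay gives 708 nM.

Compound 1 holds the lowest number of the two, and compound 2 stands clearly above it, beyond the scatter. Compound 3, `O=C(O)CCc1ccc(C#Cc2ccncc2)cc1`, has not yet been measured. It differs from compound 1 by hydrogen in place of phenyl on an aromatic carbon. Within the data shown here, no measured pair shows what removing that group does here, so the expectation rests on compound 1 alone. The change is expected to raise the number by a moderate amount, about a 3.8-fold higher number from compound 1 to compound 3 (0.58 log units; beyond the scatter). Compound 3 is therefore estimated at 700 nM, with a range from 250 nM to 2500 nM.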

Compound 3, half-maximal effective concentration: 4070 nM
For compound 3 the middle estimate is 5.8-fold (0.76 log units) below the measured one; the whole stated range lies below it.
By their numbers in this assay, from the lowest: compound 1; then compound 2; then compound 3.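

In this assay, putting hydrogen in place of the phenyl on this aromatic carbon, next to the ring nitrogen, gives a 22-fold higher number from compound 1 to compound 3 (1.34 log units; beyond the scatter) and marks this as a position where the group present strongly changes the number. The phenyl thus cannot be removed here without a large loss. Nothing available explains why the step is so large.

From the compounds shown here alone, it remains open whether a small group such as methyl or an amine at this carbon would recover part of that loss. Going by these compounds, it is equally open whether a phenyl bearing a fluorine or a methoxy group would lower the number further.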